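The compounds below may be only part of what the source reports. "The series", "measured", "known", "first", "only" and "open" are said of these compounds alone.

Compound 1 `Cc1ccc(-c2cc(NC(=O)/C=C/c3ccc(C(F)(F)F)cc3)n[nH]2)cc1` gives 720 nM in a functional assay on MCF7 cells (Homo sapiens) for antiproliferative activity, read by MTT assay, with a stated time of 48 h; on this read-out higher numbers stand for weaker inhibition and lower numbers for stronger inhibition. Compound 2 `Cc1ccc(-c2cc(NC(=O)/C=C/c3ccc(Br)cc3)n[nH]2)cc1` gives 1370 nM in this assay, and compound 3 `COc1ccc(/C=C/C(=O)Nc2cc(-c3ccc(C)cc3)[nH]n2)cc1` gives 860 nM. Compound 3 stands second highest of the three numbers: its nearest neighbour is compound 1, where the gap is a 1.2-fold higher number from compound 1 to compound 3 (0.08 log units; within the scatter), and its furthest is compound 2, with a 1.6-fold lower number from compound 2 to compound 3 (0.20 log units; within the scatter). Compound 1 and compound 2 are separated by a 1.9-fold higher number from compound 1 to compound 2 (0.28 log units; within the scatter). All three steps sit within the scatter, so none of the three groups on the aromatic carbon has yet separated itself from the others in this assay.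

Compound 4 `Cc1ccc(-c2cc(NC(=O)/C=C/c3ccc(F)cc3)n[nH]2)cc1` has not been measured. Its change from compound 3 is fluoro in place of methoxy on an aromatic carbon. Every measured step is an exchange at this same aromatic carbon, and none of them moved the number in this assay beyond the scatter, so the expected step is a 1.2-fold higher number from compound 3 to compound 4 (0.07 log units; within the scatter), again within the scatter. In this assay compound 4 is therefore estimated at 1000 nM, with a range from 400 nM to 2500 nM.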

Compound 4, half-maximal inhibitory concentration: 950 nM
Beside the measured number, compound 4's estimate is 1.1-fold (0.02 log units) above it; measured number inside the range.
By their numbers in this assay, from the lowest: compounds 1, 3, 4 and 2 (each within the scatter of the next).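

Fluoro joins trifluoromethyl, bromo and methoxy at this aromatic carbon, and in this assay each of its three exchanges stays within the scatter (a 1.1-fold higher number from compound 3 to compound 4 (0.04 log units; within the scatter); a 1.4-fold lower number from compound 2 to compound 4 (0.16 log units; within the scatter); a 1.3-fold higher number from compound 1 to compound 4 (0.12 log units; within the scatter)). The change from 4-methoxyphenyl to 4-fluorophenyl goes from 2 heavy atoms to 1 and from 1 hydrogen-bond acceptor to 0, so among these compounds neither the oxygen nor its acceptor count separates the number from that of fluoro. No measurement at hand accounts for this flat response.

From the compounds shown here alone, whether an amine, a carboxylic acid or a longer chain such as butoxy at this aromatic carbon would move the number beyond the scatter remains open. The compounds shown also say nothing about exchanges elsewhere on the shared core.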